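Chloro added to the cyanophenyl arm of compound 1

A few compounds are considered here, and "the series" means these few. Any claim that something is new, unique, unknown or untested is made for them only; others in the source may bear on it.

Measured compounds:
compound 1 `Cc1ccc2ccc(-c3cccc(C#N)c3)cc2n1`, 7.7 nM
compound 2 `COCc1cccc(-c2ccc3ccc(C)nc3c2)c1`, 5800 nM
compound 3 `Cc1ccc2ccc(-c3cccc(CO)c3)cc2n1`, 8700 nM

In a functional assay on CHO cells for inhibition of metabotropic glutamate receptor 5 (Rattus norvegicus), read by FLIPR and calcium flux (a lower number here means a stronger inhibitor, a higher number a weaker inhibitor), compound 1 gives the lowest of the three numbers; the others stand far away, as the steps of a 750-fold higher number from compound 1 to compound 2 (2.88 log units; beyond the scatter) and a 1100-fold higher number from compound 1 to compound 3 (3.05 log units; beyond the scatter) show. Both of those steps remove the cyano group and replace it with a group carrying oxygen; the step of a 1.5-fold higher number from compound 2 to compound 3 (0.18 log units; within the scatter) between those two oxygen-bearing compounds is within the scatter.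

Compound 4 `Cc1ccc2ccc(-c3cc(Cl)cc(C#N)c3)cc2n1` keeps the cyano group of compound 1 and differs from it in one place: chloro in place of hydrogen on an aromatic carbon. Among the measured compounds shown here, no measured step describes adding a chloro while the cyano group stays, so the two large steps from compound 1 do not bear directly on this change; they only show that the cyano group itself is what compound 1 and compound 4 share. With the cyano retained, the step of a 1.0-fold higher number from compound 1 to compound 4 (0.02 log units; within the scatter) is expected to be small, likely within the scatter, in either direction. Compound 4 is therefore estimated at 8 nM, with a range from 2 nM to 35 nM.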

Compound 4, half-maximal inhibitory concentration: 1.4 nM
Beside the measured number, compound 4's estimate is 5.7-fold (0.76 log units) above it; measured number outside the range, below it.
By their numbers in this assay, from the lowest: compound 4; then compound 1; then compounds 2 and 3 (each within the scatter of the next).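

In this assay, chloro in place of hydrogen on the aromatic carbon meta to a cyano group gives a 5.5-fold lower number from compound 1 to compound 4 (0.74 log units; beyond the scatter), a step beyond the scatter towards stronger inhibition. The earlier steps shown here changed only the cyano group itself, whereas this one shows that the arm can take a substituent elsewhere with the cyano group kept, and that the number can still fall from the already low value of compound 1. No accompanying measurement bears on the origin of this gain.

From the compounds shown here alone, whether fluoro, bromo, methyl or an amine at this carbon would match chloro remains open. Also open, going by these compounds, is whether chloro would lower the number with the methoxymethyl of compound 2 or the hydroxymethyl of compound 3 in place of the cyano group.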